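Swapping furan-2-yl for thiophen-3-yl on the shared core

The source may report more compounds than this note shows. Statements on the series, on what has been measured and on what is new or still open speak of the compounds shown alone.

compound 1 `COc1ncnc2c1c(-c1ccccc1)cn2[C@@H]1O[C@H](CO)[C@@H](O)[C@H]1O` gives > 20000 nM (a limit)
compound 2 `COc1ncnc2c1c(-c1cc3ccccc3o1)cn2[C@@H]1O[C@H](CO)[C@@H](O)[C@H]1O` gives 13800 nM
compound 3 `CNc1ncnc2c1c(-c1ccco1)cn2[C@@H]1O[C@H](CO)[C@@H](O)[C@H]1O` gives 230 nM

In a functional assay on HCT-116 cells (Homo sapiens), read by MTT assay, with a stated time of 72 h (on this read-out higher numbers stand for weaker inhibition and lower numbers for stronger inhibition), compound 3 gives 230 nM as the lowest of the numbers shown. Compound 2 gives 13800 nM and lies beyond the scatter from that number. Compound 1 reports only a limit at > 20000 nM and no number.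

Compound 4 `CNc1ncnc2c1c(-c1ccsc1)cn2[C@@H]1O[C@H](CO)[C@@H](O)[C@H]1O` has not yet been measured. It carries thiophen-3-yl in place of furan-2-yl on an aromatic carbon, and the change is thiophen-3-yl in place of furan-2-yl on an aromatic carbon in full. Among the measured compounds shown here, the one measured swap at this place is an at least 1.4-fold lower number from compound 1 to compound 2 (0.16 log units; that floor lies within the scatter) and its size is only a floor set by the limit of > 20000 nM in this assay, at which 1 of the 3 values shown sits, in a pair that holds neither of these two groups. That step therefore gives little guide to size or direction, and no step beyond the scatter is expected in this assay here. The expected change is a 1.3-fold higher number from compound 3 to compound 4 (0.12 log units; within the scatter) as an estimate. For compound 4 the estimated value is 300 nM with an expected range of 70 nM to 1500 nM in this estimate.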

Compound 4, half-maximal inhibitory concentration: > 20000 nM
Compound 4: no number, only a limit; the forecaster's own chance of this, stated with the estimate: 4%; middle value at least 66-fold (1.82 log units) away from the limit.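

In this assay, among the compounds shown here, the swap of furan-2-yl for thiophen-3-yl gives an at least 86-fold higher number from compound 3 to compound 4 (1.93 log units; beyond the scatter), and so, unlike the one earlier step at this place, whose floor lay within the scatter, it shows that this position can respond strongly to the ring it carries. The two rings have the same counts of heavy atoms, hydrogen-bond donors and acceptors and the same net charge, yet they differ in their hetero atom, oxygen against sulfur, and in their point of attachment. Compound 4 reports only a limit, > 20000 nM, and no number, so the size of this step is only a floor: the limit of > 20000 nM in this assay, at which 2 of the 4 values shown sit.

Going by these compounds, what thiophen-2-yl or furan-3-yl would give at this place remains open. The compounds shown therefore cannot say whether the sulfur atom or the point of attachment accounts for the step.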